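The source may hold more compounds than are shown below. What is called first, only, known or untested is meant among the compounds shown, and "the series" means these compounds.

Within the data shown here, in a functional assay on HeLa cells (Homo sapiens) for cytotoxicity, read by MTT assay (on this read-out lower numbers stand for stronger inhibition and higher numbers for weaker inhibition), compound 2 `CC[C@@](C)(O)CC(=O)O[C@H](CC=C(C)C)C1=CC(=O)c2c(O)ccc(O)c2C1=O` gives 17900 nM, the lowest of the two numbers so far; compound 1 `CC(C)=CC[C@@H](OC(=O)CC(O)c1ccccc1)C1=CC(=O)c2c(O)ccc(O)c2C1=O` gives 44500 nM. Among the measured compounds shown here, the one step known, a 2.5-fold lower number from compound 1 to compound 2 (0.40 log units; beyond the scatter), is modest. Compound 3 `CC(C)=CC[C@@H](OC(=O)c1ccoc1)C1=CC(=O)c2c(O)ccc(O)c2C1=O` carries furan-3-yl in place of 2-hydroxy-2-methylbutyl on a carbonyl carbon. That measured step touches the same place but not this change, in which the 2-hydroxy-2-methylbutyl gives way to a five-membered aromatic ring, so it offers no direct guide. A step of similar modest size in either direction, or none beyond the scatter, is plausible in this assay. Compound 3 is expected at 25000 nM, range 8000 nM to 70000 nM, meaning an estimated 1.4-fold higher number from compound 2 to compound 3 (0.15 log units; within the scatter).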

Compound 3, half-maximal inhibitory concentration: > 100000 nM
Compound 3 ended at the assay's limit; the forecaster's own chance of this, stated with the estimate: 10%; middle value at least 4.0-fold (0.60 log units) from the limit.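

In this assay compound 3 gives > 100000 nM, which is a limit of the assay and not a number. At this carbonyl carbon, furan-3-yl in place of either hydroxy-bearing chain gives an at least 5.5-fold higher number from compound 2 to compound 3 (0.74 log units; beyond the scatter) and an at least 2.2-fold higher number from compound 1 to compound 3 (0.35 log units; beyond the scatter), so the position is sensitive to more than the exchange between those two chains. Both steps are bounded, not sized, by the same ceiling: the limit of > 100000 nM in this assay, at which 1 of the 3 values shown sits.

Open, from the compounds shown here alone, is whether the hydroxy group or the chain itself matters: a plain 2-methylbutyl chain would separate the two, and furan-3-yl on a longer chain would test the ring apart from its direct attachment.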